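This account rests on a few compounds, and the source may have more. Where it says the series, first, only, none or still open, it means among the compounds named here.

Going by the values given here, compound 3 `O=C(Nc1ccc(Cl)cc1)Nc1ccc(C(=O)/C=C/c2ccc(Cl)c(Cl)c2)cc1` gives 21.6% in a functional assay on the whole organism (Abdomen, strain Swiss) for inhibition, with Mus musculus as the target, with a stated time of 30 min, at a dose of 10 mg/kg by the intraperitoneal route (a higher number here means more inhibition at the dose given (going by the name of the read-out), a lower number less inhibition), the lowest of the three numbers measured so far. Its nearest neighbour is compound 1 `Cc1ccc(/C=C/C(=O)c2ccc(NC(=O)Nc3ccc(Cl)cc3)cc2)cc1`, which in this assay gives 42.8%; the furthest is compound 2 `O=C(Nc1ccc(Cl)cc1)Nc1ccc(C(=O)/C=C/c2ccccc2)cc1`, which in this assay gives 74.6%. Both the step of a number 21.2 percentage points lower from compound 1 to compound 3 (beyond the scatter) and the step of a number 53 percentage points lower from compound 2 to compound 3 (beyond the scatter) run downward, while the step of a number 31.8 percentage points higher from compound 1 to compound 2 (beyond the scatter) leaves compound 2 with the highest number of the set.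

Compound 4 `O=C(Nc1ccc(Cl)cc1)Nc1ccc(C(=O)/C=C/c2ccc(Cl)cc2)cc1` differs from compound 3 by hydrogen in place of chloro on an aromatic carbon. The step that bears most directly on this change is a number 53 percentage points lower from compound 2 to compound 3 (beyond the scatter), the large fall from phenyl to 3,4-dichlorophenyl; a number 21.2 percentage points lower from compound 1 to compound 3 (beyond the scatter) points the same way. Going from 3,4-dichlorophenyl to 4-chlorophenyl undoes part of that change, so a rise beyond the scatter is expected, though one that need not reach the number of compound 2. Compound 4 is therefore estimated at 45%, within 25% to 68%. The expected step is a number 23.4 percentage points higher from compound 3 to compound 4 (beyond the scatter).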

Compound 4, a percentage reported as inhibition, in the whole organism at one dose (the size of the read-out at that dose, not a potency): 51%
Compound 4: the middle estimate sits 6 percentage points below what was measured; low and high end bracket the measured number.
By their numbers in this assay, from the lowest: compound 3; then compounds 1 and 4 (each within the scatter of the next); then compound 2.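

In this assay the loss of the chloro group ortho to a chloro group gives a number 29.4 percentage points higher from compound 3 to compound 4 (beyond the scatter) and so recovers part of the fall seen with 3,4-dichlorophenyl, yet a number 23.6 percentage points lower from compound 2 to compound 4 (beyond the scatter) shows that 4-chlorophenyl does not regain the number of the unsubstituted phenyl. Chloro and methyl on this ring are not told apart, with a number 8.2 percentage points higher from compound 1 to compound 4 (within the scatter) as the step between them, and both compounds stay under compound 2. Nothing at hand bears on the reason for these steps.

Open, on these data alone, is whether a methoxy group, an amine or a carboxylic acid in place of the remaining chloro would also stay under compound 2. Also open, as far as these compounds go, is how a single chloro group on the carbon vacated in compound 4 would compare with 4-chlorophenyl.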